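The source may report more compounds than this note shows. Statements on the series, on what has been measured and on what is new or still open speak of the compounds shown alone.

Measured compounds:
compound 1 `COc1ccc2nc(C)cc(OCC(=O)Nc3c(C)cccc3C)c2c1`: in a toxicity assay on HepG2 cells (Homo sapiens) for inhibition, read by CellTiter-Glo, with a stated time of 48 h (on this read-out higher numbers stand for weaker inhibition and lower numbers for stronger inhibition), compound 1 gives > 100000 nM, a limit of the assay rather than a number.
compound 2 `COc1ccc2nc(C)cc(OCC(=O)Nc3ccc(Br)c(C)c3)c2c1`: in this assay compound 2 gives 15900 nM.

Compound 2 holds the only number shown in this assay; the other value is a limit. Compound 3 `COc1ccc2nc(C)cc(OCC(=O)Nc3cccnc3)c2c1` differs from compound 2 by pyridin-3-yl in place of 4-bromo-3-methylphenyl on an amide-type nitrogen. Among the measured compounds shown here, the single measured step, an at least 6.2-fold lower number from compound 1 to compound 2 (0.79 log units; beyond the scatter), bears on this change only loosely, since it rests on the limit of > 100000 nM in this assay, at which 1 of the 2 values shown sits, and on a different aryl group; no measured step involves a pyridin-3-yl. Weaker inhibition than in compound 2 is expected, a step of a 3.8-fold higher number from compound 2 to compound 3 (0.58 log units; beyond the scatter), with a fair chance that only a limit is returned. Compound 3 is estimated at 60000 nM, range 20000 nM to 150000 nM.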

Compound 3, half-maximal inhibitory concentration: > 100000 nM
Compound 3: no number, only a limit; the forecaster's own chance of this, stated with the estimate: 45%; middle value at least 1.6-fold (0.22 log units) away from the limit.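

Pyridin-3-yl in place of 4-bromo-3-methylphenyl on the amide-type nitrogen gives an at least 6.2-fold higher number from compound 2 to compound 3 (0.79 log units; beyond the scatter) in this assay. Among the compounds shown here, a second group at this position, after 2,6-dimethylphenyl, thus returns only a limit, and compound 2 remains the only compound with a number. The step's full size stays unknown, and the step between compound 1 and compound 3 cannot be read, as both values are limits: the limit of > 100000 nM in this assay, at which 2 of the 3 values shown sit.

Still open, on these data alone, is whether a plain phenyl, or a phenyl carrying only the bromine or only the methyl, would give a number. As far as these compounds go, whether chlorine in place of the bromine would do so is also open.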